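Swapping an oxygen-linked chain for a sulfur-bearing one

This account rests on a few compounds, and the source may have more. Where it says the series, first, only, none or still open, it means among the compounds named here.

Among the measured compounds shown here, compound 2 `CCC(=O)Oc1cc(/C=C/C(=O)c2ccc(OC)c3c2OC(C)(C)C=C3)ccc1OC` gives 160 nM in a functional assay on K562 cells (Homo sapiens) for cytotoxicity, read by MTT assay (a higher number here means a weaker inhibitor, a lower number a stronger inhibitor), the lowest of the three numbers measured so far. Compound 3 `COc1ccc(/C=C/C(=O)c2ccc(OC)c3c2OC(C)(C)C=C3)cc1OC(=O)C1CC1` gives 410 nM, and compound 1 `COc1ccc(/C=C/C(=O)c2ccc(OC)c3c2OC(C)(C)C=C3)cc1OCCO` gives 8750 nM. The step of a 2.6-fold higher number from compound 2 to compound 3 (0.41 log units; beyond the scatter) is modest, whereas a 55-fold lower number from compound 1 to compound 2 (1.74 log units; beyond the scatter) and a 21-fold lower number from compound 1 to compound 3 (1.33 log units; beyond the scatter) are both large, so what hangs from this oxygen on the aromatic ring clearly matters.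

Compound 4 `COc1ccc(/C=C/C(=O)c2ccc(OC)c3c2OC(C)(C)C=C3)cc1CS(C)(=O)=O` has not yet been measured. It differs from compound 2 by (methylsulfonyl)methyl in place of propanoyloxy on an aromatic carbon: the entering group is joined to the ring through carbon rather than oxygen. For the measured compounds named here, none of the measured steps changes the linking atom in this way, so the earlier steps only show that this place is sensitive, not which way the number will move. A sizeable change is therefore expected, more likely toward a higher number, with wide uncertainty. Compound 4 is expected to give about 1500 nM, with a range from 300 nM to 8000 nM. This estimate means a step of a 9.4-fold higher number from compound 2 to compound 4 (0.97 log units; beyond the scatter).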

Compound 4, half-maximal inhibitory concentration: 9240 nM
Estimate against measurement, compound 4: 6.2-fold (0.79 log units) below; measured number above the stated range.
By their numbers in this assay, from the lowest: compound 2; then compound 3; then compounds 1 and 4 (each within the scatter of the next).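

The (methylsulfonyl)methyl group matches propanoyloxy in heavy atoms and hydrogen-bond acceptors, yet in this assay the change gives a 58-fold higher number from compound 2 to compound 4 (1.76 log units; beyond the scatter) and, against the cyclopropyl partner, a 23-fold higher number from compound 3 to compound 4 (1.35 log units; beyond the scatter) in the same sentence of results, so matching those counts does not preserve the low number. By contrast, a 1.1-fold higher number from compound 1 to compound 4 (0.02 log units; within the scatter) leaves (methylsulfonyl)methyl and 2-hydroxyethoxy indistinguishable here, and among these four compounds only compound 2 and compound 3, which carry a carbonyl on the ring oxygen, reach the low numbers. Nothing available explains these differences.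

From the compounds shown here alone, the linking atom and the end group change together in this step, so it remains open which one matters; a 2-oxobutyl group, joined through carbon but keeping a carbonyl, would separate them. Going by these compounds, how a longer acyl chain such as butanoyl on the same oxygen, or an amine at this place, would behave also remains open.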